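Toward compound 4: a formyl-bearing enyl chain in place

The compounds below may be only part of what the source reports. "The series", "measured", "known", "first", "only" and "open" are said of these compounds alone.

Measured so far:
Compound 1, `C=CC(=C)[C@@H](O)C[C@H]1C(=C)CC[C@@H]2[C@]1(C)CCC[C@]2(C)C(=O)O`, in a functional assay on SMMC-7721 cells (Homo sapiens) for cytotoxicity, read by MTT assay, with a stated time of 48 h (a lower number here means a stronger inhibitor, a higher number a weaker inhibitor), gives > 40000 nM, a limit of the assay and not a number.
Compound 2, `C=CC(=C)CC[C@@H]1[C@@]2(C)CCC[C@](C)(COC(=O)/C=C\c3ccc(O)c(OC)c3)[C@@H]2CC[C@@]1(C)O`, gives 7500 nM in this assay.
Compound 3, `C=C1CC[C@@H]2[C@](C)(CCC[C@@]2(C)C(=O)O)[C@H]1CC/C(C)=C/COC(C)=O`, gives only a limit in this assay, > 40000 nM.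

Compound 1 thus stands at the limit of > 40000 nM in this assay, at which 2 of the 3 values shown sit, so nothing is known of how far beyond that limit its true value lies. Compound 4, `C=C1CC[C@@H]2[C@](C)(CCC[C@]2(C)C(=O)O)[C@H]1C/C=C(\C)C=O`, has not yet been measured in this assay. It differs from compound 1 at one place: a group of 5 heavy atoms (4 carbon, 1 oxygen; no ring) in place of a group of 6 heavy atoms (5 carbon, 1 oxygen; no ring), on a saturated chain carbon bound to a saturated ring carbon. Going by the values given here, no pair of measured compounds differs at a single place, so no measured step guides the size of this change; only compound 2, with its number inside the measurable range, shows that a compound of this family can register at all. Given that compound 1 sits at a limit, the step from compound 1 to compound 4 is expected to be an at least 1.6-fold lower number from compound 1 to compound 4 (0.20 log units; that floor lies within the scatter), in the direction of stronger inhibition but with wide uncertainty. Compound 4 is therefore estimated at 25000 nM, within a range from 7000 nM to 80000 nM.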

Compound 4, half-maximal inhibitory concentration: > 40000 nM
Compound 4: no number, only a limit (the forecaster's own chance of this, stated with the estimate: 45%); middle value at least 1.6-fold (0.20 log units) from the limit.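

Compound 1 and compound 4 each give only a limit, so no step between them can be read: the limit of > 40000 nM in this assay, at which 3 of the 4 values shown sit.

The compounds shown leave open where the true values of compound 1 and compound 4 lie, and whether the 2-formylprop-1-en-1-yl group changes anything in this assay.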